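Butoxy in place of 4-methylpiperidinyl on a shared core

The compounds below may be only part of what the source reports. "The series", "measured", "known", "first", "only" and "open" are said of these compounds alone.

Three measured compounds share a core bearing an amide, a tert-butyl group and a methanesulfonamide. Compound 1 `CC(C(=O)NCc1ccc(C(C)(C)C)nc1OCc1ccc(F)cc1)c1ccc(NS(C)(=O)=O)c(F)c1` gives 0.8 nM in an assay on cells for antagonist activity at transient receptor potential cation channel subfamily V member 1 (Homo sapiens), read by FLIPR and calcium flux, with a stated time of 6 min; on this read-out higher numbers stand for weaker inhibition and lower numbers for stronger inhibition. Among the compounds with values here, compound 2 `CCCCCCSc1nc(C(C)(C)C)ccc1CNC(=O)C(C)c1ccc(NS(C)(=O)=O)c(F)c1` gives 1.5 nM in this assay; the step of a 1.9-fold higher number from compound 1 to compound 2 (0.27 log units; within the scatter) is the only single-point comparison among the measured set. Compound 3 `CC1CCN(c2cc(C(C)(C)C)ccc2CNC(=O)C(C)c2ccc(NS(C)(=O)=O)c(F)c2)CC1` gives 0.7 nM, the lowest of the three numbers; compound 1 sits within the scatter of it, while compound 2 lies beyond it.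

Compound 4 `CCCCOc1cc(C(C)(C)C)ccc1CNC(=O)C(C)c1ccc(NS(C)(=O)=O)c(F)c1` differs from compound 3 by butoxy in place of 4-methylpiperidin-1-yl on an aromatic carbon. Within the data shown here, no measured step covers this exact exchange. Among the measured compounds shown here, the one step that bears on it, a change of the group in the same region of the core, a 1.9-fold higher number from compound 1 to compound 2 (0.27 log units; within the scatter), stayed within the scatter, and compounds 1, 2 and 3 all carry different groups at that position yet give numbers close to one another. A step of the same modest size is therefore expected, with no confident direction, for this assay. The estimated step of a 1.7-fold higher number from compound 3 to compound 4 (0.23 log units; within the scatter) stays within the usual scatter. Compound 4 is expected to give about 1.2 nM, with a range from 0.4 nM to 4 nM.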

Compound 4, inhibition constant: 1.4 nM
The estimate for compound 4 lay 1.2-fold (0.07 log units) below the measured number; low and high end bracket the measured number.
By their numbers in this assay, from the lowest: compounds 3, 1, 4 and 2 (each within the scatter of the next, the first and the last beyond it).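

In this assay, putting the open butoxy chain in place of the six-membered non-aromatic ring of 4-methylpiperidin-1-yl on this aromatic carbon gives a 2.0-fold higher number from compound 3 to compound 4 (0.30 log units; within the scatter), so for this pair the ring is not required to keep the numbers within the scatter of each other. The exchange also puts oxygen instead of nitrogen on the aromatic carbon and leaves a smaller group by heavy atoms, and even these combined differences do not carry the step beyond the scatter. No measurement at hand accounts for this tolerance of the exchange.

From the compounds shown here alone, it remains open whether this aromatic carbon would tolerate groups further from those seen here, such as a short methoxy group, a primary amine or a carboxylic acid, and whether a piperidine without the methyl group would sit as close to compound 3 as butoxy does. Going by these compounds, the shared tert-butyl group also stays open, since it is not known whether the same exchange would give a step of similar size with a trifluoromethyl group in its place.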